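This account rests on a few compounds, and the source may have more. Where it says the series, first, only, none or still open, it means among the compounds named here.

In a functional assay on A-375 cells (Homo sapiens) for antiproliferative activity, read by MTT assay, with a stated time of 24 h, tested at 0.02 ug/mL (on this read-out lower numbers stand for a weaker effect and higher numbers for a stronger effect at the one concentration tested), compound 1, `Cc1c(C(=O)Nc2ccc(-c3ccccc3)cc2)nc2ccccc2c1O`, gives 0.06%. Compound 2, `COc1ccc2nc(C(=O)Nc3ccc(-c4ccccc4)cc3)c(C)c(C(=O)O)c2c1`, gives in this assay 0.68%, nominally the higher of the two numbers, though the gap to compound 1 falls within the usual scatter, so the pair stands together near zero. Compound 3, `Cc1c(C(=O)Nc2ccc(-c3ccccc3)cc2)nc2ccccc2c1C(=O)O`, is compound 2 with hydrogen in place of methoxy on an aromatic carbon. Going by the values given here, with no comparable step measured, the expected change in this assay is a number 0.2 percentage points lower from compound 2 to compound 3 (within the scatter), none beyond the scatter. Compound 3 is therefore estimated at 0.5%, in the range 0% to 5%.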

Compound 3, a percentage reported as inhibition, at one concentration (the size of the read-out at that concentration, not a potency): 0.12%
For compound 3 the middle estimate is 0.4 percentage points above the measured one; low and high end bracket the measured number.
By their numbers in this assay, from the lowest: compounds 1, 3 and 2 (each within the scatter of the next).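

In this assay hydrogen in place of methoxy on this aromatic carbon gives a number 0.6 percentage points lower from compound 2 to compound 3 (within the scatter) and so separates the two groups by nothing this read-out can resolve. Carboxy in place of hydroxy on an aromatic carbon gives a number 0.1 percentage points higher from compound 1 to compound 3 (within the scatter) and likewise leaves the read-out unresolved, so neither change moves the compounds away from one another. No measurement at hand offers an explanation for these numbers. As far as these compounds go, whether an amine or an ethoxy group on this aromatic carbon would give a number beyond the scatter stays open.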